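The source may report more compounds than this note shows. Statements on the series, on what has been measured and on what is new or still open speak of the compounds shown alone.

Measured so far:
Compound 1 `COc1cc2nc(N3CCN(c4ccncn4)CC3)nc(N)c2cc1OC` in an assay on brain for binding affinity to Adrenergic receptor alpha-1 (Rattus norvegicus); on this read-out lower numbers stand for stronger inhibition and higher numbers for weaker inhibition: 0.27 nM
Compound 2 `CCCOc1ccnc(N2CCN(c3nc(N)c4cc(OC)c(OC)cc4n3)CC2)n1` in this assay: 0.32 nM

Compound 2 stands at the top of these two numbers, yet compound 1 lies within the scatter of it: a 1.2-fold higher number from compound 1 to compound 2 (0.07 log units; within the scatter). Compound 3 `COc1cc2nc(N3CCN(c4nccc(N(C)C)n4)CC3)nc(N)c2cc1OC` differs from compound 2 by dimethylamino in place of propoxy on an aromatic carbon. Going by the values given here, no measured step swaps these two groups directly; the single step in hand, a 1.2-fold higher number from compound 1 to compound 2 (0.07 log units; within the scatter), exchanged the whole heteroaryl and stayed within the scatter, so it bears only loosely. The expected step is a 1.1-fold higher number from compound 2 to compound 3 (0.04 log units; within the scatter), not beyond the scatter. Compound 3 is accordingly estimated at 0.35 nM, within 0.12 nM to 1 nM.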

Compound 3, inhibition constant: 0.27 nM
Beside the measured number, compound 3's estimate is 1.3-fold (0.11 log units) above it; the measured number falls inside the stated range.
By their numbers in this assay, from the lowest: compounds 1, 3 and 2 (each within the scatter of the next).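

The direct exchange in this assay gives a 1.2-fold lower number from compound 2 to compound 3 (0.07 log units; within the scatter) and so, on this aromatic carbon next to the ring nitrogen, dimethylamino and propoxy cannot be told apart. The wider exchange gives no change at the digits printed from compound 1 to compound 3 (within the scatter) and so puts 4-(dimethylamino)pyrimidin-2-yl level with pyrimidin-4-yl as well. Nothing at hand accounts for this insensitivity.

Open is whether a primary amine, a morpholine or a carboxylic acid on this carbon would stay within the scatter of these compounds. Going by these compounds, a chain longer than propoxy is equally open.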